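Shortening the hydroxycarbamoyl chain of compound 1

The source may hold more compounds than are shown below. What is called first, only, known or untested is meant among the compounds shown, and "the series" means these compounds.

Measured so far in an ADME assay on L02 cells (Homo sapiens) for cytotoxicity, read by MTT assay, with a stated time of 72 h (a lower number here means a stronger inhibitor, a higher number a weaker inhibitor), and each value a limit
compound 1 `C=CC(=O)Nc1cc2c(Nc3ccc(OCc4cccc(F)c4)c(Cl)c3)ncnc2cc1OCc1cn(CCCCC(=O)NO)nn1` gives > 25000 nM (a limit)
compound 2 `C=CC(=O)Nc1cc2c(Nc3cccc(Cl)c3F)ncnc2cc1OCc1cn(CCCCC(=O)NO)nn1` gives > 25000 nM (a limit)
compound 3 `C=CC(=O)Nc1cc2c(Nc3ccc(F)c(Cl)c3)ncnc2cc1OCc1cn(CCCC(=O)NO)nn1` gives > 25000 nM (a limit)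

Compound 1 stands at > 25000 nM as a limit and not a number. Among the compounds with values here, the series offers only the limit of > 25000 nM in this assay, at which 3 of the 3 values shown sit, and no measured step between two compounds.

Compound 4 `C=CC(=O)Nc1cc2c(Nc3ccc(OCc4cccc(F)c4)c(Cl)c3)ncnc2cc1OCc1cn(CCC(=O)NO)nn1` keeps the core of compound 1 and differs only in its chain. The difference hydroxycarbamoyl in place of 2-(hydroxycarbamoyl)ethyl on a saturated chain carbon, two bonds along the chain from an aromatic nitrogen is hydroxycarbamoyl in place of 2-(hydroxycarbamoyl)ethyl on a saturated chain carbon, two bonds along the chain from an aromatic nitrogen. Cut one bond further out, it reads 4-(hydroxycarbamoyl)butyl to 2-(hydroxycarbamoyl)ethyl.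

No shift beyond the usual scatter, in either direction, is expected in this assay for this change. The expected step of a number no higher from compound 1 to compound 4 (the limit leaves the size open) is an estimate only. Within the data shown here, that expectation rests on compound 1 at > 25000 nM as a limit, with no measured step to refine it. Compound 4 is estimated at 25000 nM with an expected range from 12000 nM to 50000 nM and a report of only a limit is the likelier outcome.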

Compound 4, half-maximal inhibitory concentration: > 25000 nM
Compound 4: only a limit was reported; the forecaster's own chance of this, stated with the estimate: 75%; the middle value lies on the limit itself.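

Compound 4, like compound 1, is reported in this assay only as a limit and not a number, so no step between the two can be read: the limit of > 25000 nM in this assay, at which 4 of the 4 values shown sit.

The compounds shown leave open what number any of them would give, and so whether 2-(hydroxycarbamoyl)ethyl in place of 4-(hydroxycarbamoyl)butyl shifts the read-out at all.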